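This account rests on a few compounds, and the source may have more. Where it says the series, first, only, none or still open, it means among the compounds named here.

Compound 1 `Cc1coc(C(=O)CCCCCCc2ccccc2)n1` carries a methyl group on its aromatic core, and in an assay on isolated protein for inhibition of Fatty-acid amide hydrolase 1 (Rattus norvegicus) (a higher number here means a weaker inhibitor, a lower number a stronger inhibitor), compound 1 gives 520 nM, the highest of the two numbers recorded so far. Going by the values given here, its only measured neighbour is compound 2 `O=Cc1coc(C(=O)CCCCCCc2ccccc2)n1`, in which a formyl group stands in place of that methyl; in this assay compound 2 gives 55 nM, so that a 9.5-fold lower number from compound 1 to compound 2 (0.98 log units; beyond the scatter). The compound now in question, compound 3 `O=C(CCCCCCc1ccccc1)c1nc(C(=O)C(F)(F)F)co1`, changes the same position in a related way: (trifluoromethyl)carbonyl in place of methyl on an aromatic carbon. Among the compounds with values here, the one measured step that bears on this change is the one from compound 1 to compound 2, where replacing the methyl with a carbonyl-bearing group lowered the number by a modest amount that was clearly beyond the scatter. On that basis a drop of similar or somewhat larger size is expected for compound 3, again in the direction of stronger inhibition, which corresponds to an expected step of a 26-fold lower number from compound 1 to compound 3 (1.41 log units; beyond the scatter). For compound 3 in this assay the estimated value is 20 nM, with a likely range from 3 nM to 100 nM.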

Compound 3, inhibition constant: 470 nM
Compound 3: middle estimate off by 24-fold (1.37 log units), on the low side; measured number outside the range, above it.
By their numbers in this assay, from the lowest: compound 2; then compounds 3 and 1 (each within the scatter of the next).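

In this assay, the step from methyl to (trifluoromethyl)carbonyl comes out as a 1.1-fold lower number from compound 1 to compound 3 (0.04 log units; within the scatter) and stays within the scatter, so a carbonyl-bearing group on this aromatic carbon does not in itself bring the gain seen with formyl. Trifluoromethyl in place of the hydrogen on the carbonyl carbon gives an 8.5-fold higher number from compound 2 to compound 3 (0.93 log units; beyond the scatter) and thereby takes back nearly all of that gain, which shows that the result at this position depends on what the carbonyl carbon bears, something the single earlier step could not reveal. Compound 2 now stands apart as the strongest inhibitor of the three, with steps to both others beyond the scatter. Nothing in the data given accounts for this result.

As far as these compounds go, it remains open whether other carbonyl-bearing groups on this carbon, such as a carboxylic acid, a methyl ester or an amide, would side with formyl or with (trifluoromethyl)carbonyl. From the compounds shown here alone, it is equally open whether the same steps would hold on a shorter or longer chain than the one shared by all three compounds.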